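Amide-type nitrogen substituent in the sulfonate series

The compounds below may be only part of what the source reports. "The series", "measured", "known", "first", "only" and "open" are said of these compounds alone.

In an assay on HEK293 cells for antagonist activity at P2X purinoceptor 7 (Homo sapiens), read by fluorescence, with a stated time of 2 h (a lower number here means a stronger inhibitor, a higher number a weaker inhibitor), compound 1 `O=C(c1ccc(Cl)c(C(F)(F)F)c1)N1CCC(n2cncc2-c2ccc(OS(=O)(=O)c3cccc([N+](=O)[O-])c3)cc2)CC1` gives 249 nM. Compound 2 `N#Cc1cccc(S(=O)(=O)Oc2ccc(-c3cncn3C3CCN(C(=O)c4ccc(Cl)c(C(F)(F)F)c4)CC3)cc2)c1` gives 73 nM, and compound 3 `CNC(=O)c1cccc(S(=O)(=O)Oc2ccc(-c3cncn3C3CCN(C(=O)c4ccc(Cl)c(C(F)(F)F)c4)CC3)cc2)c1` gives 112 nM, which places compound 3 second highest of the three numbers. The gap to its nearest neighbour is within the scatter: a 1.5-fold higher number from compound 2 to compound 3 (0.19 log units; within the scatter). The gap to its furthest neighbour is beyond it: a 2.2-fold lower number from compound 1 to compound 3 (0.35 log units; beyond the scatter). The largest measured step is a 3.4-fold lower number from compound 1 to compound 2 (0.53 log units; beyond the scatter). Compound 4 `O=C(NC1CC1)c1cccc(S(=O)(=O)Oc2ccc(-c3cncn3C3CCN(C(=O)c4ccc(Cl)c(C(F)(F)F)c4)CC3)cc2)c1` differs from compound 3 by cyclopropyl in place of methyl on an amide-type nitrogen. All three measured steps change the substituent on the aromatic carbon and leave the amide-type nitrogen unchanged, so none bears directly on this change. With nothing to go on, a step within the scatter is expected, a 1.0-fold lower number from compound 3 to compound 4 (0.01 log units; within the scatter). Compound 4 is therefore estimated at 110 nM, between 50 nM and 250 nM.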

Compound 4, half-maximal inhibitory concentration: 88 nM
For compound 4 the middle estimate is 1.3-fold (0.10 log units) above the measured one, within the range that was stated.
By their numbers in this assay, from the lowest: compounds 2, 4 and 3 (each within the scatter of the next); then compound 1.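

Cyclopropyl in place of methyl on the amide-type nitrogen leaves the number within the scatter (a 1.3-fold lower number from compound 3 to compound 4 (0.10 log units; within the scatter)), the first reading of a change at this nitrogen. The cyclopropylcarbamoyl group also stays within the scatter of cyano (a 1.2-fold higher number from compound 2 to compound 4 (0.08 log units; within the scatter)) and holds a modest gain over nitro (a 2.8-fold lower number from compound 1 to compound 4 (0.45 log units; beyond the scatter)). Nothing at hand gives a reason for these readings.

Still open, going by these compounds, is how a longer chain, such as n-butyl, or a 2-hydroxyethyl group on this nitrogen would read. Also open, on these data alone, is how a carboxylic acid would compare with these amides on the aromatic carbon.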